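This account rests on a few compounds, and the source may have more. Where it says the series, first, only, none or still open, it means among the compounds named here.

Working notes on the series. Three compounds share one core and differ only in the aryl group attached to it: compound 1 `COc1ccc(-c2cn3ccnc3c(-c3ccc4ncn(C5CCCCC5)c4c3)n2)cc1`, compound 2 `c1ccc2c(-c3cn4ccnc4c(-c4ccc5ncn(C6CCCCC6)c5c4)n3)cccc2c1` and compound 3 `CC(=O)c1ccc(-c2cn3ccnc3c(-c3ccc4ncn(C5CCCCC5)c4c3)n2)cc1`. In a physicochemical assay for lipophilicity, using the shake flask method, in phosphate buffer, measured as octanol-water partition, with a stated time of 85 min, at pH 7.4 (a higher number here means a more lipophilic compound, a lower number a more polar compound), compound 1 gives 1.41, compound 2 gives 1.44 and compound 3 gives 2.06. Compound 3 stands highest of the three: a number 0.65 log units higher from compound 1 to compound 3 (beyond the scatter) and a number 0.62 log units higher from compound 2 to compound 3 (beyond the scatter), while a number 0.03 log units higher from compound 1 to compound 2 (within the scatter).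

The next compound is compound 4 `Clc1ccc(-c2cn3ccnc3c(-c3ccc4ncn(C5CCCCC5)c4c3)n2)cc1`, which arises from compound 3 by chloro in place of acetyl on an aromatic carbon. Going by the values given here, no measured step in this assay exchanges acetyl for chloro, so the two steps into compound 3 are the only ones that bear on the position concerned. Both were modest and both ran upward toward the acetyl compound; which way a chloro group at the same place moves the number is not shown by any pair here.

On this footing the value of compound 4 in this assay is expected to lie near 2.3, with a range from 1.6 to 3. That estimate means a step of a number 0.24 log units higher from compound 3 to compound 4 (within the scatter), a change expected to be small given that the nearest measured steps into compound 3 were themselves only modest.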

Compound 4, partition coefficient: 1.51
The estimate for compound 4 lay 0.79 log units above the measured number, and the stated range ends above it.
By their numbers in this assay, from the lowest: compounds 1, 2 and 4 (each within the scatter of the next); then compound 3.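

In this assay, going by these compounds alone, the exchange of acetyl for chloro on this aromatic carbon, para to a large group, gives the first downward step at this position (a number 0.55 log units lower from compound 3 to compound 4 (beyond the scatter)), so the upward steps into compound 3 do not carry over to every replacement of acetyl. The two further steps (a number 0.07 log units higher from compound 2 to compound 4 (within the scatter)) and (a number 0.10 log units higher from compound 1 to compound 4 (within the scatter)) place the 4-chlorophenyl compound level with the naphthalen-1-yl and 4-methoxyphenyl compounds, which leaves compound 3 as the only one of the four whose steps to all the others lie beyond the scatter. Nothing at hand accounts for this separation of the acetyl compound from the other three.

As far as these compounds go, whether another carbonyl-bearing group at the same place, such as a methyl ester or a primary amide, would sit with acetyl or with the other three remains open, as does the reading for an amine or a carboxylic acid there. The compounds shown also leave open whether the gap between acetyl and chloro would hold with a group other than cyclohexyl on the shared core.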